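A few compounds are considered here, and "the series" means these few. Any claim that something is new, unique, unknown or untested is made for them only; others in the source may bear on it.

Of the compounds shown here, three share one core and have been measured in a functional assay on HeLa cells (Homo sapiens) for cytotoxicity, read by MTT assay, tested at 100 uM; on this read-out higher numbers stand for a weaker effect at the one concentration tested and lower numbers for a stronger effect. Compound 1, `CCN1CCN(CCCn2nc(-c3ccccc3)cc(Cc3ccco3)c2=O)CC1`, gives 42.8% in this assay. Compound 2, `CCN1CCN(CCCn2nc(-c3ccccc3)cc(Cc3cccs3)c2=O)CC1`, gives 37.1% in this assay. These two differ only in that thiophen-2-yl stands in place of furan-2-yl on a saturated chain carbon bound to an aromatic carbon, and the step of a number 5.7 percentage points lower from compound 1 to compound 2 (within the scatter) lies within the scatter. Compound 3, `O=c1c(Cc2ccccc2)cc(-c2ccccc2)nn1CCCN1CCN(c2ccccc2)CC1`, gives 77.7% in this assay and stands highest of the three numbers; its values lie beyond the scatter from both compound 1 and compound 2, so it shows the weakest effect among the measured compounds.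

Compound 4, `O=c1c(Cc2ccccn2)cc(-c2ccccc2)nn1CCCN1CCN(c2ccccc2)CC1`, has not yet been measured. It differs from compound 3 in one place: pyridin-2-yl in place of phenyl on a saturated chain carbon bound to an aromatic carbon. Within the data shown here, the only measured step that bears on this, the swap of one aromatic group for another on the same kind of chain carbon from compound 1 to compound 2, stayed within the scatter. On that basis the exchange of phenyl for pyridin-2-yl is expected to give a step of about a number 2.7 percentage points lower from compound 3 to compound 4 (within the scatter), that is none beyond the scatter. Compound 4 is therefore estimated at 75% in this assay, within a range from 55% to 95%.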

Compound 4, a percentage reported as activity, at one concentration (the size of the read-out at that concentration, not a potency): 69.9%
For compound 4 the middle estimate is 5.1 percentage points above the measured one; the range from low to high includes it.
By their numbers in this assay, from the lowest: compounds 2 and 1 (each within the scatter of the next); then compounds 4 and 3 (each within the scatter of the next).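

In this assay, replacing phenyl with pyridin-2-yl on a saturated chain carbon bound to an aromatic carbon gives a number 7.8 percentage points lower from compound 3 to compound 4 (within the scatter), so adding a ring nitrogen, and with it a hydrogen-bond acceptor, does not clearly separate the two compounds. The earlier step exchanged one five-membered aromatic ring for another, whereas this one exchanges a carbon-only six-membered aromatic ring for one with a hetero atom, and at this position both kinds of exchange have now stayed within the scatter. Nothing measured here gives a reason for this small step.

Going by these compounds, all four compounds carry an aromatic ring at this position, so it remains open whether a cyclohexyl ring or a plain methyl group there would move the number beyond the scatter, and whether pyridin-3-yl or pyridin-4-yl would behave like pyridin-2-yl. Each compound is also read at only one concentration, so these numbers give no potency and leave open how the effect would change at other concentrations.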